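Ethoxy for methylpiperazine at the assay limit

The source may report more compounds than this note shows. Statements on the series, on what has been measured and on what is new or still open speak of the compounds shown alone.

Compound 1 `CN1CCN(C(=O)/C=C/c2ccncc2-c2ccc3ccccc3c2)CC1` gives > 10000 nM in a functional assay on KB cells (Homo sapiens) for inhibition, read by sulforhodamine B assay, with a stated time of 72 h (on this read-out higher numbers stand for weaker inhibition of growth and lower numbers for stronger inhibition of growth), which is a limit of the assay and not a number. Compound 2 `CCOC(=O)/C=C/c1ccncc1-c1ccc2c(cnn2C)c1` gives > 10000 nM, again a limit, and it carries an ethoxycarbonyl on a different core. So far the series shows only (the limit of > 10000 nM in this assay, at which 2 of the 2 values shown sit).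

Compound 3 `CCOC(=O)/C=C/c1ccncc1-c1ccc2ccccc2c1` keeps the core of compound 1 and changes one group: ethoxy in place of 4-methylpiperazin-1-yl on a carbonyl carbon. In words, this puts ethoxy in place of 4-methylpiperazin-1-yl on a carbonyl carbon. Among the compounds with values here, no measured step gives the size of this change. Within the data shown here, with no active compound yet to set a direction, no shift beyond the scatter is expected in this assay, and the expected step is a step that the limit leaves unreadable from compound 1 to compound 3. Compound 3 may well report only a limit too. The estimate for compound 3 is 12000 nM, with an expected range of 3000 nM to 40000 nM.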

Compound 3, concentration for 50% growth inhibition: > 10000 nM
Compound 3 gave a limit, no number (the forecaster's own chance of this, stated with the estimate: 65%); the middle value does not contradict the limit.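

No step can be read between compound 1 and compound 3, since both report only a limit in this assay: the limit of > 10000 nM in this assay, at which 3 of the 3 values shown sit.

The compounds shown leave open whether ethoxy and 4-methylpiperazin-1-yl on the carbonyl carbon differ at all in growth inhibition.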